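Amide-side change on the aryl sulfonate series

The compounds below may be only part of what the source reports. "The series", "measured", "known", "first", "only" and "open" are said of these compounds alone.

The series shares an aryl sulfonate core carrying an acylated aniline. Compound 1 `CC(C)C(=O)Nc1cccc(S(=O)(=O)Oc2ccccc2C(C)C)c1` gives 13000 nM in a functional assay on MCF7 cells (Homo sapiens) for antiproliferative activity, read by sulforhodamine B assay, with a stated time of 48 h; a lower number here means a stronger inhibitor, a higher number a weaker inhibitor. Compound 2 `CC(C)c1ccccc1OS(=O)(=O)c1ccc(NC(=O)CCCl)cc1` gives 9000 nM in this assay, and compound 3 `O=C(CCCl)Nc1ccc(S(=O)(=O)Oc2ccccc2I)cc1` gives 8900 nM. Among the compounds with values here, the one single-point step among them, a 1.0-fold lower number from compound 2 to compound 3 (0.00 log units; within the scatter), shows no effect. Compound 3 therefore stands in a band with compounds 2 and 1, all three values within the scatter of one another, with no ordering that the numbers support.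

Compound 4 `O=C(NCC1CCCC1)Nc1ccc(S(=O)(=O)Oc2ccccc2I)cc1` differs from compound 3 by (cyclopentylmethyl)amino in place of 2-chloroethyl on a carbonyl carbon. Within the data shown here, no measured step touches this part of the molecule: the only step available, from compound 2 to compound 3, concerns the aromatic carbon, and compounds 1 and 2 differ in two places at once. Since every change seen so far left the number within the scatter, the expectation for compound 4 is a step of a 1.0-fold higher number from compound 3 to compound 4 (0.00 log units; within the scatter), which amounts to none beyond the scatter. Compound 4 is thus estimated at 9000 nM, with a range from 3000 nM to 30000 nM.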

Compound 4, half-maximal inhibitory concentration: 6600 nM
Compound 4: middle estimate off by 1.4-fold (0.13 log units), on the high side; the range from low to high includes it.
By their numbers in this assay, from the lowest: compounds 4, 3, 2 and 1 (each within the scatter of the next).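

The carbonyl position now has a measured step of its own: (cyclopentylmethyl)amino in place of 2-chloroethyl gives a 1.3-fold lower number from compound 3 to compound 4 (0.13 log units; within the scatter) in this assay. A substantial swap on this carbon, bringing in a five-membered non-aromatic ring and a hydrogen-bond donor and removing the chlorine, therefore leaves compound 4 in the same band as compound 3, so for this pair the 2-chloroethyl group is not needed to hold a value of this size. No supporting measurements are available to account for this result.

Going by these compounds, whether an amine, a carboxylic acid or a longer chain on this carbonyl carbon would move the number beyond the scatter remains open. On the aromatic carbon, iodo has been compared only with isopropyl, so a fluoro or methoxy group there is also an open question.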